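The source may hold more compounds than are shown below. What is called first, only, known or untested is meant among the compounds shown, and "the series" means these compounds.

Among the compounds with values here, in a functional assay on DU-145 cells (Homo sapiens) for inhibition, read by trypan blue exclusion, with a stated time of 96 h (a higher number here means a weaker inhibitor of growth, a lower number a stronger inhibitor of growth), compound 2 (`O=C(O)c1ccc(C(=O)/C(=C\c2ccc(F)c([N+](=O)[O-])c2)SCc2ccc(C(F)(F)F)cc2)cc1`) gives 1000 nM and compound 3 (`O=C(O)c1ccc(C(=O)/C(=C\c2ccc(Cl)c([N+](=O)[O-])c2)SCc2ccc(C(F)(F)F)cc2)cc1`) gives 1000 nM as well, together the lowest of the three numbers so far. Compound 1 (`Cc1ccc(CS/C(=C/c2c(O)cc(O)cc2O)C(=O)c2ccc(Cl)cc2)cc1`) sits much higher at 50000 nM but differs from compound 2 in several places, so its gap cannot be pinned on any single group. Compound 4 (`O=C(O)c1ccc(C(=O)/C(=C\c2ccc(F)c([N+](=O)[O-])c2)SCc2ccccc2Cl)cc1`) keeps the rest of compound 2 and makes one change on a saturated chain carbon bound to a sulfur, with 2-chlorophenyl in place of 4-(trifluoromethyl)phenyl (2-chlorophenyl in place of 4-(trifluoromethyl)phenyl on a saturated chain carbon bound to a sulfur). Within the data shown here, the only measured single-place step, chloro in place of fluoro on an aromatic carbon, shows no change at the digits printed from compound 2 to compound 3 (within the scatter) and leaves this group untouched. No measurement therefore tests the new change directly, and the data suggest no direction for it. The working expectation stays close to compound 2 at 1000 nM with a wide margin, and the estimate is a 1.5-fold higher number from compound 2 to compound 4 (0.18 log units; within the scatter) in this assay with nothing expected beyond the scatter. Compound 4 is expected at 1500 nM with an estimated range of 500 nM to 5000 nM for repeated measurements.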

Compound 4, concentration for 50% growth inhibition: 1000 nM
Estimate against measurement, compound 4: 1.5-fold (0.18 log units) above; the measured number falls inside the stated range.
By their numbers in this assay, from the lowest: compounds 2, 3 and 4 (each within the scatter of the next); then compound 1.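

In this assay, putting 2-chlorophenyl in place of 4-(trifluoromethyl)phenyl on a saturated chain carbon bound to a sulfur gives no change at the digits printed from compound 2 to compound 4 (within the scatter). Within the data shown here, the earlier single-place step left this position untouched, so this is the only direct reading of it so far: one substituted phenyl ring can replace the other without a shift beyond the scatter. Nothing available explains why this swap leaves the number in place.

On these data alone, what a plain hexyl chain, or a benzyl ring carrying an amine, would do at this position stays open. As far as these compounds go, it is also open whether the same swap would read the same way on the core of compound 1 or compound 3.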